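Fluoro for Chloro on the Nitrophenyl Ring

The source may hold more compounds than are shown below. What is called first, only, known or untested is meant among the compounds shown, and "the series" means these compounds.

Compound 1, `O=C(O)c1ccc(C(=O)/C(=C\c2ccc(Cl)c([N+](=O)[O-])c2)SCc2ccc(Cl)cc2)cc1`, is known in a physicochemical assay for solubility (a lower number here means a less soluble compound, a higher number a more soluble compound), only by a limit, as compound 1 gives < 1000 ug/mL. Compound 2, `O=C(O)c1ccc(C(=O)/C(=C\c2ccc(Cl)c([N+](=O)[O-])c2)SCc2ccc(Br)cc2)cc1`, carrying bromo in place of chloro on an aromatic carbon, is likewise known only by a limit. In this assay compound 2 gives < 1000 ug/mL. Within the data shown here, the single measured step, a step that the two limits leave unreadable from compound 1 to compound 2, thus has no readable size, which rests on (the limit of < 1000 ug/mL in this assay, at which 2 of the 2 values shown sit). Compound 3, `O=C(O)c1ccc(C(=O)/C(=C\c2ccc(F)c([N+](=O)[O-])c2)SCc2ccc(Cl)cc2)cc1`, differs from compound 1 by fluoro in place of chloro on an aromatic carbon. Among the measured compounds shown here, no measured step bears directly on this change, and the one step that was measured cannot be read as a number. The account therefore expects compound 3 to stand where compound 1 stands, with a step that the limit leaves unreadable from compound 1 to compound 3 expected as no step beyond the scatter. Compound 3 is estimated at 400 ug/mL, within a range from 80 ug/mL to 1500 ug/mL.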

Compound 3, solubility: < 1000 ug/mL
Compound 3: only a limit was reported; the forecaster's own chance of this, stated with the estimate: 75%; the middle value is on the limit's open side.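

In this assay compound 3 gives < 1000 ug/mL as a limit and not a number. Compound 1 is also known only by a limit, so the step between compound 1 and compound 3 cannot be read: the limit of < 1000 ug/mL in this assay, at which 3 of the 3 values shown sit. On these data alone, the actual solubility of compound 1, compound 2 and compound 3, and whether swapping these halogens shifts it, stays open.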